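The source may report more compounds than this note shows. Statements on the series, on what has been measured and on what is new or still open speak of the compounds shown alone.

Measured so far, in a functional assay for antagonist activity at transient receptor potential cation channel subfamily V member 1 (Homo sapiens), read by calcium flux; on this read-out higher numbers stand for weaker inhibition and lower numbers for stronger inhibition: compound 1 `O=C(Nc1cccc2[nH]ncc12)NC1CCOc2c(OC(F)(F)F)cccc21` gives 5 nM; compound 2 `O=C(Nc1cccc2[nH]ncc12)NC1CCOc2c(C3CCCCC3)cccc21` gives 15 nM.

For the measured compounds named here, compound 2 holds the highest of these two numbers; its only neighbour is compound 1, and the step of a 3.0-fold higher number from compound 1 to compound 2 (0.48 log units; beyond the scatter) lies beyond the scatter. Compound 3 `O=C(Nc1cccc2[nH]ncc12)NC1CCOc2c1cccc2N1CCCCC1` differs from compound 2 in one place: piperidin-1-yl in place of cyclohexyl on an aromatic carbon. Going by the values given here, no measured step exchanges one six-membered non-aromatic ring for another at this carbon; the single step known, a 3.0-fold higher number from compound 1 to compound 2 (0.48 log units; beyond the scatter), concerns a different group there and was modest. A step of at most similar size is therefore expected in this assay, most likely none beyond the scatter. Compound 3 is estimated at 20 nM (range 6 nM to 70 nM), an expected step of a 1.3-fold higher number from compound 2 to compound 3 (0.12 log units; within the scatter).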

Compound 3, half-maximal inhibitory concentration: 16 nM
Compound 3: middle estimate off by 1.3-fold (0.10 log units), on the high side, within the range that was stated.
By their numbers in this assay, from the lowest: compound 1; then compounds 2 and 3 (each within the scatter of the next).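

In this assay the exchange of cyclohexyl for piperidin-1-yl on this aromatic carbon gives a 1.1-fold higher number from compound 2 to compound 3 (0.03 log units; within the scatter) and so no readable change, even though a ring nitrogen with one hydrogen-bond acceptor enters. Measured against trifluoromethoxy, piperidin-1-yl gives a 3.2-fold higher number from compound 1 to compound 3 (0.51 log units; beyond the scatter) as well, so compound 1 stays apart from both compounds with a six-membered ring at this carbon. No evidence is available that accounts for either step.

On these data alone, what a morpholin-4-yl or piperazin-1-yl ring, or a methoxy group, would do at this carbon stays open. So does whether cyclohexyl and piperidin-1-yl would also match on another core.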